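Swapping Methoxy for Chloro on an Inactive Amide Series

A few compounds are considered here, and "the series" means these few. Any claim that something is new, unique, unknown or untested is made for them only; others in the source may bear on it.

Compound 1, `COc1ccc(NC(=O)c2cccc(/C=C3\CC(=O)N(c4ccccc4)C3=O)c2)cc1`, in an ADME assay on HCT-116 cells (Homo sapiens) for cytotoxicity, read by MTT assay, with a stated time of 72 h (a lower number here means a stronger inhibitor, a higher number a weaker inhibitor), gives > 100000 nM, which is a limit of the assay and not a number.
Compound 2, `CCCCCN1C(=O)C/C(=C\c2cccc(C(=O)NCCCC)c2)C1=O`, in this assay gives > 100000 nM, again a limit.
Compound 3, `CCCCCN1C(=O)C/C(=C\c2cccc(C(=O)Nc3ccc(OC)cc3)c2)C1=O`, in this assay gives > 100000 nM, also a limit.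

Compound 1 therefore stands only at a limit, and so do the two compounds measured beside it; all three sit at the limit of > 100000 nM in this assay, at which 3 of the 3 values shown sit. The two measured steps, a step that the two limits leave unreadable from compound 1 to compound 3 and a step that the two limits leave unreadable from compound 2 to compound 3, cannot be read, since both ends of each lie at the limit.

Compound 4, `O=C(Nc1ccc(Cl)cc1)c1cccc(/C=C2\CC(=O)N(c3ccccc3)C2=O)c1`, is not yet measured. It differs from compound 1 in one place: chloro in place of methoxy on an aromatic carbon. Among the compounds with values here, no measured step touches this position, so nothing among the known steps speaks directly to it, and the steps that exist are unreadable in any case. With every measured compound at the limit, the expectation for compound 4 is that it also stays at the limit, and the expected step is a step that the limit leaves unreadable from compound 1 to compound 4, which means no change that can be seen. Compound 4 is thus estimated at 200000 nM, within a range from 60000 nM to 600000 nM, most likely reported only as a limit.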

Compound 4, half-maximal inhibitory concentration: > 100000 nM
Compound 4: a limit, no number; the forecaster's own chance of this, stated with the estimate: 85%; the middle value lies beyond the limit too.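

Within the data shown here, compound 4 and compound 1 both sit at a limit of the assay, so the swap of methoxy for chloro gives no step that can be read, and the same limit holds across the series: the limit of > 100000 nM in this assay, at which 4 of the 4 values shown sit. The compounds shown leave open which change to the shared core, if any, would give an actual number in this assay.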